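Compound 3: a 3-Methylthiophen-2-yl Group Enters the Core

A few compounds are considered here, and "the series" means these few. Any claim that something is new, unique, unknown or untested is made for them only; others in the source may bear on it.

Compound 1: `Cc1ccc(CS/C(=C/c2c[nH]c3ccc(Cl)cc23)C(=O)c2ccc(Cl)cc2)cc1` gives 1000 nM in a functional assay on DU-145 cells (Homo sapiens) for inhibition, read by trypan blue exclusion, with a stated time of 96 h; on this read-out lower numbers stand for stronger inhibition of growth and higher numbers for weaker inhibition of growth.
Compound 2: `O=C(/C(=C\c1c(O)cc(O)cc1O)Sc1ccc(Br)cc1)c1ccc(Cl)cc1` gives 50000 nM in this assay.

On these two numbers compound 1 stands lowest, and the gap to compound 2 is far beyond the usual scatter, so compound 1 is the stronger inhibitor of growth of the pair. Compound 3, `Cc1ccc(CS/C(=C/c2sccc2C)C(=O)c2ccc(Cl)cc2)cc1`, has not been measured. It differs from compound 1 in one place: 3-methylthiophen-2-yl in place of 5-chloro-1H-indol-3-yl on a double-bonded chain carbon bound to a double-bonded chain carbon. Among the measured compounds shown here, no measured pair shows this kind of exchange, so the expectation rests on compound 1 alone and on the size of the group that leaves against the one that enters. A move toward weaker inhibition, clearly beyond the scatter, is expected in this assay. Compound 3 is therefore estimated at 5000 nM, with a range from 1000 nM to 30000 nM. That estimate means an expected step of a 5.0-fold higher number from compound 1 to compound 3 (0.70 log units; beyond the scatter).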

Compound 3, concentration for 50% growth inhibition: 10000 nM
Estimate against measurement, compound 3: 2.0-fold (0.30 log units) below, and the stated range covers the measured number.
By their numbers in this assay, from the lowest: compound 1; then compound 3; then compound 2.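

In this assay, putting 3-methylthiophen-2-yl in place of 5-chloro-1H-indol-3-yl gives a 10-fold higher number from compound 1 to compound 3 (1.00 log units; beyond the scatter), so the group on this double-bonded chain carbon clearly matters, something compounds 1 and 2 could not show, as they differ in more than one place. The six-membered aromatic ring of carbon only, the chlorine and the hydrogen-bond donor all leave in this one change, and a sulfur and a methyl enter, so the step cannot separate their contributions. No other data bear on why inhibition of growth weakens here.

The compounds shown leave open whether the chlorine or the rest of the indole carries the difference, which a plain 1H-indol-3-yl group would help to settle. Also open, on these data alone, is how this position responds to a different kind of group, such as an amine or a carboxylic acid.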